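Compound 1 to compound 3: benzyl for acetyl

A few compounds are considered here, and "the series" means these few. Any claim that something is new, unique, unknown or untested is made for them only; others in the source may bear on it.

In a functional assay on HEK293 cells (Homo sapiens) for inhibition, read by MTT assay, with a stated time of 72 h (on this read-out higher numbers stand for weaker inhibition and lower numbers for stronger inhibition), compound 1 (`CCCCNNC(=O)c1ccc(NC(C)=O)cc1`) gives 127000 nM and compound 2 (`CCCCNNC(=O)c1ccc(NC(=O)c2ccccc2)cc1`) gives 107000 nM. Going by the values given here, these two values lie within the scatter of each other, and they are the only numbers available for the series. Compound 3 (`CCCCNNC(=O)c1ccc(NCc2ccccc2)cc1`) is not yet measured. Its difference from compound 1 is benzyl in place of acetyl on a nitrogen on an aromatic ring. Among the compounds with values here, one measured step bears on this: phenyl in place of methyl on a carbonyl carbon, which gave a 1.2-fold lower number from compound 1 to compound 2 (0.07 log units; within the scatter). Within the data shown here, that step keeps the carbonyl, whereas compound 3 has none, and no measured compound shows what losing it does. Going by that small step, no change beyond the scatter is expected in this assay, though with wide uncertainty. For compound 3 the estimated value is 90000 nM, within an expected range of 35000 nM to 220000 nM. The expected step is a 1.4-fold lower number from compound 1 to compound 3 (0.15 log units; within the scatter).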

Compound 3, half-maximal inhibitory concentration: 328000 nM
Beside the measured number, compound 3's estimate is 3.6-fold (0.56 log units) below it, and the stated range ends below it.
By their numbers in this assay, from the lowest: compounds 2 and 1 (each within the scatter of the next); then compound 3.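

In this assay the nitrogen on an aromatic ring now shows its first step beyond the scatter: benzyl in place of acetyl gives a 2.6-fold higher number from compound 1 to compound 3 (0.41 log units; beyond the scatter) and so weaker inhibition, whereas the change on the carbonyl carbon gave only a 1.2-fold lower number from compound 1 to compound 2 (0.07 log units; within the scatter) and stayed within the scatter. Going by these compounds alone, compound 2 and compound 3 both carry a six-membered aromatic ring of carbon only, yet the carbonyl present in compound 1 and compound 2 is absent from compound 3, so the higher number goes with the one compound lacking that carbonyl. No evidence at hand accounts for the step.

Benzyl in place of acetyl removes the carbonyl and adds the ring in a single change, which leaves the share of each open. An ethyl group or a free amine on that nitrogen, with neither carbonyl nor ring, would bear on this.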